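A few compounds are considered here, and "the series" means these few. Any claim that something is new, unique, unknown or untested is made for them only; others in the source may bear on it.

Measured in a functional assay on the whole organism for antagonist activity, with Mus musculus as the target; on this read-out lower numbers stand for an effect already at smaller amounts and higher numbers for an effect only at larger amounts of compound:
compound 1 `CCC(=O)N(c1ccc(Cl)c(Cl)c1)C1CCCC1N(CC)CC` gives 0.03 mg/kg
compound 2 `CCCN(CCC)C1CCCC1N(C(=O)CC)c1ccc(Cl)c(Cl)c1` gives 0.1 mg/kg

Compound 2 holds the higher of the two numbers (0.1 mg/kg). Compound 3 `CCC(=O)N(c1ccc(Cl)c(Cl)c1)C1CCCC1N(C)CCCN(C)C` has (3-(dimethylamino)propyl)(methyl)amino in place of dipropylamino on a saturated ring carbon. Within the data shown here, only one measured step bears on this place, and it is modest (a 3.3-fold higher number from compound 1 to compound 2 (0.52 log units; beyond the scatter)), with dipropylamino replacing diethylamino. Among the measured compounds shown here, no measured compound carries the new chain, so the expectation is uncertain: a step of similar or somewhat larger size towards a higher number is expected (a 4.0-fold higher number from compound 2 to compound 3 (0.60 log units; beyond the scatter)). The estimated value for compound 3 is 0.4 mg/kg with an expected range of 0.06 mg/kg to 3 mg/kg in this assay and no more than that can be said yet.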

Compound 3, dose for half-maximal effect: 10 mg/kg
For compound 3 the middle estimate is 25-fold (1.40 log units) below the measured one, outside the stated range (above it).
By their numbers in this assay, from the lowest: compound 1; then compound 2; then compound 3.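

In this assay, the saturated ring carbon proves far more sensitive to the amine than the earlier pair showed: (3-(dimethylamino)propyl)(methyl)amino gives a 100-fold higher number from compound 2 to compound 3 (2.00 log units; beyond the scatter) and a 330-fold higher number from compound 1 to compound 3 (2.52 log units; beyond the scatter). Changes at this place are therefore not limited to modest shifts such as a 3.3-fold higher number from compound 1 to compound 2 (0.52 log units; beyond the scatter). Nothing available accounts for the size of these steps.

From the compounds shown here alone, it remains open whether the terminal dimethylamino group or the chain as a whole goes with the higher number. A pyrrolidine or a longer all-carbon chain at this place would help separate the two.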